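The compounds below may be only part of what the source reports. "The series", "measured", "known", "first", "only" and "open" are said of these compounds alone.

Compound 1 `c1ccc(-c2nc[nH]n2)c(NCC2=NCCN2)c1` gives 3.98 nM in an in vitro functional assay on cells (Fibroblast) for agonist activity at Alpha-1D adrenergic receptor (Homo sapiens); on this read-out lower numbers stand for an effect already at smaller amounts and higher numbers for an effect only at larger amounts of compound.
Compound 2 `CCn1ncnc1-c1ccccc1NCC1=NCCN1` gives 126 nM in this assay.
Compound 3 `CC(C)n1nccc1-c1ccccc1NCC1=NCCN1` gives < 100000 nM in this assay, which is a limit of the assay and not a number.

Of the two numbers shown, compound 1 stands lowest, with compound 2 the nearest and beyond the scatter above it. Among the measured compounds shown here, no pair of measured compounds differs in a single place, so no measured step is available. Compound 4 `c1ccc(-c2cn[nH]c2)c(NCC2=NCCN2)c1` differs from compound 1 by 1H-pyrazol-4-yl in place of 1H-1,2,4-triazol-3-yl on an aromatic carbon. The step from compound 1 to compound 4 is expected to be a modest loss, a 5.0-fold higher number from compound 1 to compound 4 (0.70 log units; beyond the scatter), beyond the scatter. Compound 4 is therefore estimated at 20 nM in this assay, within a range from 4 nM to 150 nM.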

Compound 4, half-maximal effective concentration: 20 nM
Compound 4: the middle estimate sits on the measured number at the digits printed; low and high end bracket the measured number.
By their numbers in this assay, from the lowest: compound 1; then compound 4; then compound 2.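

In this assay, replacing 1H-1,2,4-triazol-3-yl with 1H-pyrazol-4-yl on this aromatic carbon costs only modestly, with a 5.0-fold higher number from compound 1 to compound 4 (0.70 log units; beyond the scatter). The entering ring has one hydrogen-bond acceptor instead of two and keeps its donor, so this position accepts a ring with fewer hetero atoms while compound 4 still gives 20 nM. Nothing measured here explains the step.

The compounds shown leave open whether the loss follows the acceptor count or the placement of the ring nitrogens. They also leave open how a phenyl ring or a carboxylic acid would fare at this position.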